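Ether to thioether on a fused diamine core

This account rests on a few compounds, and the source may have more. Where it says the series, first, only, none or still open, it means among the compounds named here.

Measured so far in a functional assay on A498 cells (Homo sapiens) for inhibition, read by sulforhodamine B assay, with a stated time of 48 h; a higher number here means a weaker inhibitor of growth, a lower number a stronger inhibitor of growth: compound 1 `Nc1cc(N)c2nc(-c3ccccc3)c(Oc3ccc(Cl)c(Cl)c3)nc2c1` gives 91200 nM; compound 2 `Nc1cc(N)c2nc(-c3ccccc3)c(NCc3ccc(Cl)c(Cl)c3)nc2c1` gives 17400 nM. Compound 3 `CCOC(=O)[C@H](CCC(=O)O)NC(=O)c1ccc(CNc2nc3cc(N)cc(N)c3nc2-c2ccccc2)cc1` is reported as < 100000 nM, which is a limit of the assay and not a number.

Within the data shown here, compound 1 stands at the highest of the two numbers known here, and the only other number, that of compound 2, is lower by a margin beyond the usual scatter. Compound 3 gives a limit and not a number (the limit of < 100000 nM in this assay, at which 1 of the 3 values shown sits), so it cannot be placed against the others. No pair among these three differs in a single place, so no measured step is available to lean on.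

Compound 4 `COc1ccc(Sc2nc3cc(N)cc(N)c3nc2-c2ccccc2)cc1` is the next compound to be measured. Relative to compound 1 it carries the following change ((4-methoxyphenyl)sulfanyl in place of 3,4-dichlorophenoxy on an aromatic carbon). Among the measured compounds shown here, nothing among the measured compounds isolates this exchange, so the step is a guess: in this assay a modest move downward, of a size near the edge of the scatter, seems as likely as no move at all. On that basis compound 4 is estimated at 60000 nM, with a range from 15000 nM to 150000 nM. The step this estimate implies, a 1.5-fold lower number from compound 1 to compound 4 (0.18 log units; within the scatter), is expected to be small.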

Compound 4, concentration for 50% growth inhibition: 17400 nM
The estimate for compound 4 lay 3.4-fold (0.54 log units) above the measured number, within the range that was stated.
By their numbers in this assay, from the lowest: compounds 2 and 4 (each within the scatter of the next); then compound 1.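

Among these compounds, the exchange of 3,4-dichlorophenoxy for (4-methoxyphenyl)sulfanyl on this aromatic carbon brought, in this assay, a 5.2-fold lower number from compound 1 to compound 4 (0.72 log units; beyond the scatter), the first measured step at this position, and it shows that the number responds to what the carbon carries. Compound 4 gives 17400 nM and compound 2, with a different group on the same carbon, gives 17400 nM as its printed number, so two quite different substituents here arrive at the same value. Nothing given here accounts for the size of the step.

As far as these compounds go, the exchange alters the linking atom and the substituents on the outer ring at once, so it remains open how much of the step belongs to the sulfur in place of the oxygen and how much to the methoxy group in place of the two chlorines. From the compounds shown here alone, a (3,4-dichlorophenyl)sulfanyl group or a 4-methoxyphenoxy group on the same carbon would separate these two parts of the change, and how a free amine or a carboxylic acid on the outer ring would fare is also open.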